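This account rests on a few compounds, and the source may have more. Where it says the series, first, only, none or still open, it means among the compounds named here.

Measured in a functional assay on MCF7 cells (Homo sapiens) for cytotoxicity, read by MTT assay, with a stated time of 48 h; a higher number here means a weaker inhibitor, a lower number a stronger inhibitor:

- compound 1, `FC(F)=C(F)CCSc1ncc(Cl)s1`: > 120000 nM
- compound 2, `CC(c1nccs1)C(C#N)(C#N)CCC(F)=C(F)F`: > 120000 nM
- compound 3, `O=S(=O)(CCC(F)(Cl)C(F)(F)Cl)c1nc2ccccc2s1`: 10100 nM

Compound 1 stands at a limit of this assay, not at a number; its value reports only that the half-maximal inhibitory concentration was not reached. Compound 2 sits at the same limit. Among the measured compounds shown here, compound 3 is the one compound of the three with a measured number, 10100 nM, and it carries a different core and a sulfone link, so it tells nothing direct about the step from compound 1. The limit of > 120000 nM in this assay, at which 2 of the 3 values shown sit, marks where most of the present data sit.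

The unmeasured compound 4, `FC(F)=C(F)CCSc1ncc(-c2ccncc2)s1`, keeps the core of compound 1 and differs from it in one place: pyridin-4-yl in place of chloro on an aromatic carbon.

For the measured compounds named here, no measured pair shows this kind of exchange, so the size of the step is open. With compound 1 at a limit, any movement in this assay can only appear as a gain, and a moderate gain is expected rather than none, with a real chance that compound 4 again returns only the limit. The expected step is an at least 2.0-fold lower number from compound 1 to compound 4 (0.30 log units; that floor lies within the scatter). For compound 4 the expected half-maximal inhibitory concentration is 60000 nM, estimated to lie between 15000 nM and 120000 nM.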

Compound 4, half-maximal inhibitory concentration: > 120000 nM
Compound 4 was reported as a limit; the forecaster's own chance of this, stated with the estimate: 45%; middle value at least 2.0-fold (0.30 log units) from the limit.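

In this assay, among the compounds shown here, compound 4 gives > 120000 nM, a limit and not a number; compound 1 also stands at a limit, so no step between compound 1 and compound 4 can be read. The compounds shown leave open whether pyridin-4-yl in place of chloro on an aromatic carbon changes the read-out at all, with most values at one limit: the limit of > 120000 nM in this assay, at which 3 of the 4 values shown sit.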